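Working notes: furan-2-yl to thiophen-2-yl on the carbonyl

The source may hold more compounds than are shown below. What is called first, only, known or untested is meant among the compounds shown, and "the series" means these compounds.

Measured so far in an assay on isolated protein for inhibition of DNA topoisomerase 1 (Homo sapiens), tested at 20 uM; a higher number here means a stronger effect of the compound at the concentration tested, a lower number a weaker effect:
- compound 1, `O=C(/C=C/c1ccc(F)cc1)c1ccc(O)cc1O`, gives 56.7%
- compound 2, `COc1cc(O)ccc1/C=C/C(=O)c1ccc(F)cc1`, gives 9.5%
- compound 3, `COc1ccc(/C=C/C(=O)c2ccco2)cc1Br`, gives 8.8%

Compound 3 stands lowest of the three numbers. Its nearest neighbour is compound 2, whose value lies within the scatter of compound 3, so no order between those two is claimed. Compound 1 stands far above, beyond the scatter, and is the only one of the three that rises clearly.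

Compound 4, `COc1ccc(/C=C/C(=O)c2cccs2)cc1Br`, is the next one to be measured in this assay. It differs from compound 3 in one place: thiophen-2-yl in place of furan-2-yl on a carbonyl carbon. Going by the values given here, no step between measured compounds is available in this set, and no measured pair shows a change of this kind, so the expectation rests on the change alone. The step from compound 3 to compound 4 is expected to be small, none beyond the scatter, in no set direction.

Compound 4 is estimated at 12%, with a range from 2% to 28%. The expected step is a number 3.2 percentage points higher from compound 3 to compound 4 (within the scatter).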

Compound 4, a percentage reported as inhibition, at one concentration (the size of the read-out at that concentration, not a potency): 2.1%
Estimate against measurement, compound 4: 9.9 percentage points above; low and high end bracket the measured number.
By their numbers in this assay, from the lowest: compounds 4, 3 and 2 (each within the scatter of the next); then compound 1.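

In this assay, the first step read at this position, thiophen-2-yl in place of furan-2-yl on a carbonyl carbon, gives a number 6.7 percentage points lower from compound 3 to compound 4 (within the scatter) and so cannot be told from repeat scatter. The two groups match in everything counted for them, heavy atoms, ring size, donors and acceptors, and differ only in the ring hetero atom, sulfur for oxygen; in this pair, that exchange leaves no order between compound 3 and compound 4. No measurement of any property of these two groups is available to bear on this result.

Going by these compounds, whether a group of another kind on this carbonyl carbon, such as an amine or a carboxylic acid, would move the read-out beyond the scatter stays open. Also open, on these data alone, is whether the same exchange gives an equally small step on a different core.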